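Compound 3 and the unmeasured compound 4

The compounds below may be only part of what the source reports. "The series", "measured", "known", "first", "only" and "open" are said of these compounds alone.

Compound 1 `CC(C)n1ncc2c(C(=O)Nc3c(F)cccc3F)cc(-c3cccs3)nc21`: > 200000 nM (a limit)
Compound 2 `CC(C)n1ncc2c(C(=O)Nc3ccc(F)c(F)c3)cc(-c3cccs3)nc21`: > 200000 nM (a limit)
Compound 3 `CC(C)n1ncc2c(C(=O)Nc3ccccc3S(N)(=O)=O)cc(-c3cccs3)nc21`: 25000 nM

Among the measured compounds shown here, in an ADME assay on LLC-MK2 cells (Macaca mulatta) for cytotoxicity, read by spectrophotometry and crystal violet staining, with a stated time of 4 days (a lower number here means that less compound is tolerated, a higher number that more compound is tolerated), compound 3 gives 25000 nM, the only actual number. The other two results are not numbers: the limit of > 200000 nM in this assay, at which 2 of the 3 values shown sit.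

Compound 4 `CC(C)n1ncc2c(C(=O)Nc3ccncn3)cc(-c3cccs3)nc21`, not yet measured, carries pyrimidin-4-yl in place of 2-sulfamoylphenyl on an amide-type nitrogen.

For the measured compounds named here, two measured steps bear on this change: an at least 8.0-fold lower number from compound 1 to compound 3 (0.90 log units; beyond the scatter) and an at least 8.0-fold lower number from compound 2 to compound 3 (0.90 log units; beyond the scatter). Both bring in 2-sulfamoylphenyl and both lie beyond the scatter, though neither shows what pyrimidin-4-yl does. Its removal is therefore expected to reverse part of that drop, giving a 4.0-fold higher number from compound 3 to compound 4 (0.60 log units; beyond the scatter).

Compound 4 is estimated at 100000 nM, with an expected range from 40000 nM to 200000 nM.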

Compound 4, half-maximal cytotoxic concentration: 50000 nM
Beside the measured number, compound 4's estimate is 2.0-fold (0.30 log units) above it; low and high end bracket the measured number.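

In this assay, the change to pyrimidin-4-yl gives a 2.0-fold higher number from compound 3 to compound 4 (0.30 log units; within the scatter), so these two different groups on the amide-type nitrogen cannot be told apart here. Compound 4 also gives an at least 4.0-fold lower number from compound 2 to compound 4 (0.60 log units; beyond the scatter) and an at least 4.0-fold lower number from compound 1 to compound 4 (0.60 log units; beyond the scatter), so the lower number seen earlier does not require 2-sulfamoylphenyl. Compound 1 and compound 2 remain at a limit, not a number: the limit of > 200000 nM in this assay, at which 2 of the 4 values shown sit.

The compounds shown leave open whether an unsubstituted phenyl or a pyridin-2-yl on the amide-type nitrogen would stand with the difluorophenyl compounds or with compound 3 and compound 4.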